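Swapping a chlorinated aromatic arm for a hexyl chain

A few compounds are considered here, and "the series" means these few. Any claim that something is new, unique, unknown or untested is made for them only; others in the source may bear on it.

Measured so far in a functional assay on K562 cells (Homo sapiens) for cytotoxicity, read by MTT assay, with a stated time of 72 h; on this read-out higher numbers stand for weaker inhibition and lower numbers for stronger inhibition:
Compound 1, `[O-][n+]1nc(NCOCc2ccc(Cl)cc2)[n+]([O-])c2ccccc21`, gives 3260 nM.
Compound 2, `[O-][n+]1nc(NCOCc2ccc(C(F)(F)F)cc2)[n+]([O-])c2ccccc21`, gives 18300 nM.
Compound 3, `CC(OCNc1n[n+]([O-])c2ccccc2[n+]1[O-])c1ccccc1`, gives 8720 nM.

Compound 1 holds the lowest number of the three in this assay; compound 3 stands nearest to it and compound 2 furthest, both beyond the scatter. The set contains a single step between compounds that differ in one place: a 5.6-fold higher number from compound 1 to compound 2 (0.75 log units; beyond the scatter).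

Compound 4, `CCCCCCCOCNc1n[n+]([O-])c2ccccc2[n+]1[O-]`, remains to be measured. Its difference from compound 1 is as follows.
hexyl in place of 4-chlorophenyl on a saturated chain carbon bound to an oxygen on a saturated carbon

Among the measured compounds shown here, no measured step addresses this kind of change. For the measured compounds named here, the step from compound 1 to compound 2 exchanges one substituent on the aromatic ring for another, whereas here the ring itself leaves and a chain enters; compound 3 rearranges the aromatic arm but has no single-point step to compound 1. The data therefore offer only indirect guidance. Both measured departures from compound 1 gave higher numbers, and because a 5.6-fold higher number from compound 1 to compound 2 (0.75 log units; beyond the scatter) went upward, a further upward drift seems the more likely outcome, though with wide uncertainty. The estimate for compound 4 means a 2.5-fold higher number from compound 1 to compound 4 (0.39 log units; beyond the scatter). Compound 4 is accordingly estimated at 8000 nM in this assay, with a range from 2500 nM to 25000 nM.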

Compound 4, half-maximal inhibitory concentration: 2970 nM
Compound 4: the middle estimate sits 2.7-fold (0.43 log units) above what was measured, within the range that was stated.
By their numbers in this assay, from the lowest: compounds 4 and 1 (each within the scatter of the next); then compound 3; then compound 2.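

In this assay, the change from an aromatic arm to an open chain reads as a 1.1-fold lower number from compound 1 to compound 4 (0.04 log units; within the scatter), so hexyl in place of 4-chlorophenyl on a saturated chain carbon bound to an oxygen on a saturated carbon leaves the number within the scatter. Among these compounds, then, the six-membered aromatic ring is not needed at this place for a number of this size, whereas the only earlier single-place change, which kept the ring and put trifluoromethyl in place of chloro, gave a 5.6-fold higher number from compound 1 to compound 2 (0.75 log units; beyond the scatter). Nothing available explains why the whole ring can leave without a change beyond the scatter while that substituent exchange produces one.

The compounds shown leave open whether a shorter chain such as butyl, a longer chain such as decyl, or a branched chain would keep the number within the scatter of compound 1 at this place. They also leave open how a hexyl chain ending in an amine or a carboxylic acid, or a saturated cyclohexyl ring in place of the chain, would read in this assay.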